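Dichloro for Amino on the Ketone-Bearing Ring

A few compounds are considered here, and "the series" means these few. Any claim that something is new, unique, unknown or untested is made for them only; others in the source may bear on it.

Two members of this series have numbers in a functional assay on MCF7 cells (Homo sapiens) for cytotoxicity, read by sulforhodamine B assay, with a stated time of 48 h, tested at 1 uM; a higher number here means a weaker effect of the compound at the concentration tested, a lower number a stronger effect. Compound 2 `COc1cc(-c2cc(/C=C/C(=O)c3ccc(N)cc3)[nH]n2)cc(OC)c1OC` stands highest of the two: in this assay compound 2 gives 66%, the weaker effect at the tested concentration. Its nearest neighbour is compound 1 `COc1ccc(-c2cc(/C=C/C(=O)c3ccc(N)cc3)[nH]n2)cc1`, which in this assay gives 42%, a gap that lies beyond the usual scatter. Within the data shown here, those two differ from each other at another place than the one followed here, and no single-point step between measured compounds is known.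

Compound 3 `COc1cc(-c2cc(/C=C/C(=O)c3ccc(Cl)c(Cl)c3)[nH]n2)cc(OC)c1OC` has not yet been measured. Compared with compound 2 it shows (3,4-dichlorophenyl in place of 4-aminophenyl on a carbonyl carbon). Among the measured compounds shown here, no measured pair shows what this exchange does, so its size and direction are open. The step from compound 2 to compound 3 is expected to be modest, a number 8 percentage points lower from compound 2 to compound 3 (within the scatter), with either direction possible. Compound 3 is expected to give about 58% in this assay, between 30% and 85%.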

Compound 3, a percentage reported as activity, at one concentration (the size of the read-out at that concentration, not a potency): 62%
Compound 3: middle estimate off by 4 percentage points, on the low side; measured number inside the range.
By their numbers in this assay, from the lowest: compound 1; then compounds 3 and 2 (each within the scatter of the next).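

In this assay, among these compounds, the first step at this position can now be read: 3,4-dichlorophenyl in place of 4-aminophenyl on a carbonyl carbon gives a number 4 percentage points lower from compound 2 to compound 3 (within the scatter). The exchange removes the amino nitrogen, takes the hydrogen-bond donors and acceptors of this group to zero and adds two chlorine atoms, yet on the core of compound 2 the read-out at the tested concentration does not separate the two compounds. Nothing at hand accounts for this outcome.

From the compounds shown here alone, whether the exchange behaves the same way on the core of compound 1 remains open, since this single step rests on one core and one concentration. Also open, going by these compounds, is what a lone 4-chlorophenyl, a 4-hydroxyphenyl or a phenyl bearing a carboxylic acid would give on that carbonyl carbon.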